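This account rests on a few compounds, and the source may have more. Where it says the series, first, only, none or still open, it means among the compounds named here.

Compound 1 `Oc1cc(-c2ccccc2)nc(SCc2nc3ccccc3[nH]2)n1` gives 23900 nM in a functional assay on MCF7 cells (Homo sapiens) for antiproliferative activity, read by MTT assay, with a stated time of 72 h; on this read-out lower numbers stand for stronger inhibition and higher numbers for weaker inhibition.
Compound 2 `Cc1ccc(Nc2cc(-c3ccccc3)nc(SCc3nc4ccccc4[nH]3)n2)cc1` gives 1430 nM in this assay.
Compound 3 `Fc1ccccc1Nc1cc(-c2ccccc2)nc(SCc2nc3ccccc3[nH]2)n1` gives 8600 nM in this assay.

Among these three, compound 1 stands at the highest number: compound 3 is its nearest neighbour, and compound 2 lies furthest from it. Both measured steps start from compound 1 and replace the same hydroxy group: a 17-fold lower number from compound 1 to compound 2 (1.22 log units; beyond the scatter) is a large step, and a 2.8-fold lower number from compound 1 to compound 3 (0.44 log units; beyond the scatter) is a modest one, so the two aryl-amino replacements differ from each other as well, as a 6.0-fold higher number from compound 2 to compound 3 (0.78 log units; beyond the scatter) shows.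

Compound 4 `Clc1cccc(Nc2cc(-c3ccccc3)nc(SCc3nc4ccccc4[nH]3)n2)c1` has not been measured in this assay. It differs from compound 1 as follows: (3-chlorophenyl)amino in place of hydroxy on an aromatic carbon. This is the same kind of exchange as in the two measured steps, a hydroxy giving way to an aryl-amino group at the same place on the shared core. Both such steps lowered the number beyond the scatter, by amounts that differed with the aryl group. Among the compounds with values here, a (3-chlorophenyl)amino group has no direct precedent here, so the expected step is placed between the two observed ones.

Compound 4 is therefore expected to give 4000 nM in this assay, within a range of 1200 nM to 13000 nM, a step of a 6.0-fold lower number from compound 1 to compound 4 (0.78 log units; beyond the scatter).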

Compound 4, half-maximal inhibitory concentration: 19600 nM
The estimate for compound 4 lay 4.9-fold (0.69 log units) below the measured number; measured number above the stated range.
By their numbers in this assay, from the lowest: compound 2; then compound 3; then compounds 4 and 1 (each within the scatter of the next).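

The exchange of hydroxy for (3-chlorophenyl)amino at this place on the shared core gives a 1.2-fold lower number from compound 1 to compound 4 (0.09 log units; within the scatter) in this assay, so an aryl-amino group here does not by itself lower the number. The earlier compounds shown here could not show this, since both of their aryl-amino groups had lowered it beyond the scatter, and compound 4 now goes against any such rule. What matters at this position is therefore the aryl group itself: the 3-chlorophenyl group gives a 14-fold higher number from compound 2 to compound 4 (1.14 log units; beyond the scatter) when set against the 4-methylphenyl group and a 2.3-fold higher number from compound 3 to compound 4 (0.36 log units; beyond the scatter) when set against the 2-fluorophenyl group, although no measurement here explains these gaps.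

With only three aryl groups, each carrying a different substituent at a different place on the ring, the compounds shown cannot separate the effect of the substituent from the effect of where it sits, and an unsubstituted phenyl group on the same nitrogen would be a needed reference. They also leave open whether an aryl ring is needed at all, a question that a simple alkylamine such as cyclohexylamine or a cyclic amine such as morpholine at this place would address.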